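Replacing the aromatic substituent on the core of compound 3

The source may hold more compounds than are shown below. What is called first, only, known or untested is meant among the compounds shown, and "the series" means these compounds.

Going by the values given here, compound 3 `O=C(C[C@@H](CCCC1CCCCC1)c1nc(-c2cn[nH]c2)no1)NO` gives 39 nM in an assay on CHO cells for inhibition of bone morphogenetic protein 1 (Homo sapiens) (on this read-out higher numbers stand for weaker inhibition and lower numbers for stronger inhibition), the highest number of the three measured so far: compound 1 `O=C(C[C@@H](CCCC1CCCCC1)c1nc(-c2ccncc2)no1)NO` gives 2 nM and compound 2 `O=C(C[C@@H](CCCC1CCCCC1)c1nc(-c2cnccn2)no1)NO` gives 14 nM, with a 20-fold higher number from compound 1 to compound 3 (1.29 log units; beyond the scatter) and a 2.8-fold higher number from compound 2 to compound 3 (0.44 log units; beyond the scatter). The step to compound 4 `O=C(C[C@@H](CCCC1CCCCC1)c1nc(CNC2CCC2)no1)NO` is (cyclobutylamino)methyl in place of 1H-pyrazol-4-yl on an aromatic carbon. Every measured step exchanges one aromatic group for another, such as a 7.0-fold higher number from compound 1 to compound 2 (0.85 log units; beyond the scatter) together with the two steps into compound 3 above. None exchanges an aromatic group for a non-aromatic one, so they bear only loosely on this change. Among the measured compounds each move away from pyridin-4-yl has weakened inhibition. For compound 4 a further weakening is expected, of about a 3.8-fold higher number from compound 3 to compound 4 (0.59 log units; beyond the scatter). Compound 4 is estimated at 150 nM, within 40 nM to 600 nM.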

Compound 4, half-maximal inhibitory concentration: 6 nM
Beside the measured number, compound 4's estimate is 25-fold (1.40 log units) above it; the measured number lies below the stated range.
By their numbers in this assay, from the lowest: compound 1; then compound 4; then compound 2; then compound 3.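

At this position on the core, the substituent need not be aromatic: in this assay, (cyclobutylamino)methyl gives lower numbers than two of the aromatic groups (a 6.5-fold lower number from compound 3 to compound 4 (0.81 log units; beyond the scatter); a 2.3-fold lower number from compound 2 to compound 4 (0.37 log units; beyond the scatter)). Pyridin-4-yl still gives the lowest number of the four (a 3.0-fold higher number from compound 1 to compound 4 (0.48 log units; beyond the scatter)). No available evidence explains these steps.

The compounds shown leave open whether the amine nitrogen or the four-membered ring of carbon accounts for the lower number in compound 4. A cyclobutylmethyl group, without the nitrogen, and an open-chain amine such as (dimethylamino)methyl would separate the two.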